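Dropping a Methoxy Group: Does Growth Inhibition Follow?

This account rests on a few compounds, and the source may have more. Where it says the series, first, only, none or still open, it means among the compounds named here.

Compound 3 `COc1ccc2[nH]c(-c3ccccc3)c(/C=C(\C#N)S(=O)(=O)c3ccccc3)c2c1` and compound 4 `N#C/C(=C\c1c(-c2ccccc2)[nH]c2ccccc12)S(=O)(=O)c1ccccc1` share a core whose difference from that of compound 2 `COc1ccc(-c2[nH]c3ccc(OC)cc3c2C=C(C#N)C#N)cc1` is not broken down here. In a functional assay on SN12C cells (Homo sapiens) for inhibition, read by sulforhodamine B assay, with a stated time of 48 h (a higher number here means a weaker inhibitor of growth, a lower number a stronger inhibitor of growth), compound 3 gives 7800 nM, compound 2 gives 15900 nM and compound 1 `COc1ccc2[nH]c(-c3ccccc3)c(C=C(C#N)C#N)c2c1` gives 4700 nM. Compound 1 arises from compound 2 by hydrogen in place of methoxy on an aromatic carbon, a step that gave a 3.4-fold lower number from compound 2 to compound 1 (0.53 log units; beyond the scatter). Compound 4 arises from compound 3 by hydrogen in place of methoxy on an aromatic carbon, the same kind of change but not the same: in compound 2 the methoxy is para to a large group, whereas in compound 3 it is part of a fused or bridged system of two rings, meta to a fused ring and para to a fused ring. Because a 3.4-fold lower number from compound 2 to compound 1 (0.53 log units; beyond the scatter) favoured the hydrogen, the expected step of a 1.4-fold lower number from compound 3 to compound 4 (0.15 log units; within the scatter) points the same way but is smaller. Compound 4 is thus estimated at 5500 nM, between 2500 nM and 14000 nM.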

Compound 4, concentration for 50% growth inhibition: 5200 nM
The estimate for compound 4 lay 1.1-fold (0.02 log units) above the measured number; measured number inside the range.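

In this assay, putting hydrogen in place of methoxy gave a 1.5-fold lower number from compound 3 to compound 4 (0.18 log units; within the scatter), a step too small on its own to separate from the scatter of repeated measurements. Set beside the earlier step, it gives no sign that the change behaves differently on the two cores: the same change on two cores in this assay, a 3.4-fold lower number (0.53 log units; beyond the scatter) from compound 2 to compound 1 and a 1.5-fold lower number (0.18 log units; within the scatter) from compound 3 to compound 4, 2.3-fold (0.35 log units) apart, within the scatter of two such steps. This does not show that the two steps are truly equal in size or that hydrogen is better than methoxy on the second core, and two pairs are too few to make a rule for the series.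

The compounds shown carry only methoxy or hydrogen at these places. From the compounds shown here alone, how a hydroxyl group, a chlorine atom or an amine would fare there stays open.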